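Swapping the furan for a cyanopyridine on the shared core

The source may report more compounds than this note shows. Statements on the series, on what has been measured and on what is new or still open speak of the compounds shown alone.

Three compounds share one core carrying an amino group, an aromatic group at one position and a benzyl-type side chain at another. Compound 1 `Cc1ccc(-c2nc(N)c3cc(CCc4ccccc4)sc3n2)o1` gives 2780 nM in a functional assay on CHO-K1 cells for antagonist activity at adenosine receptor A1 (Homo sapiens), read by a beta-galactosidase reporter and cAMP accumulation, with stated times of 15 min and 6 h; a higher number here means a weaker inhibitor, a lower number a stronger inhibitor. Compound 2 `CCc1ccc(-c2nc(N)c3cc(Cc4ccccc4)sc3n2)o1` gives 223 nM in this assay, the lowest of the two numbers, with compound 1 giving the higher number, beyond the scatter. Compound 3 `C=C(c1ccccc1)c1cc2c(N)nc(-c3cccc(C#N)c3)nc2s1` gives > 1000 nM in this assay, which is a limit of the assay and not a number (the limit of > 1000 nM in this assay, at which 1 of the 3 values shown sits). Compound 4 `N#Cc1cccc(-c2nc(N)c3cc(Cc4ccccc4)sc3n2)n1` is not yet measured; it differs from compound 2 in one place: 6-cyanopyridin-2-yl in place of 5-ethylfuran-2-yl on an aromatic carbon. Among the measured compounds shown here, no measured step covers such a change, so the expected step of a 3.6-fold higher number from compound 2 to compound 4 (0.55 log units; beyond the scatter) is judged uncertain and leaning toward weaker. Compound 4 is therefore estimated at 800 nM, within 200 nM to 3000 nM.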

Compound 4, inhibition constant: > 1000 nM
Compound 4 gave a limit, no number (the forecaster's own chance of this, stated with the estimate: 30%); middle value at least 1.2-fold (0.09 log units) away from the limit.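

Within this assay, this is the only step shown at this position with the rest of the molecule held fixed: placing 6-cyanopyridin-2-yl where 5-ethylfuran-2-yl stood gives an at least 4.4-fold higher number from compound 2 to compound 4 (0.65 log units; beyond the scatter). So this replacement does not keep the strength of the ethylfuran compound. Compound 4 gives a limit and not a number, so the step is only a lower bound on the loss: the limit of > 1000 nM in this assay, at which 2 of the 4 values shown sit.

On these data alone, whether the weakening belongs to the pyridine ring or to its nitrile stays open. A plain pyridin-2-yl group at this position would tell the two apart.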